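A few compounds are considered here, and "the series" means these few. Any claim that something is new, unique, unknown or untested is made for them only; others in the source may bear on it.

Working notes on the series. Compound 1 `O=C(CC1CCCC1)Nc1c(C(O)(C(F)(F)F)C(F)(F)F)ccc2ccccc12` and compound 2 `O=C(Nc1c(C(O)(C(F)(F)F)C(F)(F)F)ccc2ccccc12)c1ccc(Cl)cc1` share the same core and differ only at the group on the carbonyl carbon of the amide. In an assay on LtK cells with ATP-sensitive inward rectifier potassium channel 11 (Homo sapiens) as the target (on this read-out lower numbers stand for an effect already at smaller amounts and higher numbers for an effect only at larger amounts of compound), compound 1 gives 81 nM, and in the same assay compound 2 gives 570 nM. Among the compounds with values here, the one step measured so far, a 7.0-fold higher number from compound 1 to compound 2 (0.85 log units; beyond the scatter), is the whole of what is known about the amide side; on these two numbers compound 2 stands at the higher end, with compound 1 as its only neighbour.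

Compound 3 `O=C(Nc1c(C(O)(C(F)(F)F)C(F)(F)F)ccc2ccccc12)c1cccc(Cl)c1Cl` is not yet measured. It departs from compound 2 by 2,3-dichlorophenyl in place of 4-chlorophenyl on a carbonyl carbon. Within the data shown here, no measured step touches a change of this kind: the single step in hand swaps an aryl group for a saturated one, whereas here an aryl group is kept and only its chlorine pattern changes. An expectation for compound 3 therefore rests on compound 2 alone and is loose. The working estimate for compound 3 in this assay is 500 nM, with a range from 150 nM to 2000 nM, meaning an expected step of a 1.1-fold lower number from compound 2 to compound 3 (0.06 log units; within the scatter), with no direction beyond the scatter that can be argued from the data.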

Compound 3, half-maximal effective concentration: > 10000 nM
Compound 3 ended at the assay's limit; the forecaster's own chance of this, stated with the estimate: 5%; at least 20-fold (1.30 log units) between middle value and limit.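

Compound 3 gives > 10000 nM in this assay, and this value is a limit of the assay, not a number: the limit of > 10000 nM in this assay, at which 1 of the 3 values shown sits. The earlier step exchanged a saturated group for an aryl group, so it could not show whether the pattern on a retained aryl group matters; here the aryl group stays on the carbonyl carbon and the change to 2,3-dichlorophenyl still gives an at least 17-fold higher number from compound 2 to compound 3 (1.24 log units; beyond the scatter). Against the cyclopentylmethyl amide, the same position now spans an at least 120-fold higher number from compound 1 to compound 3 (2.09 log units; beyond the scatter), and across the three compounds shown the order runs from cyclopentylmethyl through 4-chlorophenyl to 2,3-dichlorophenyl, with every step beyond the scatter.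

Which of the two chlorines in 2,3-dichlorophenyl accounts for the step stays open, and the limit leaves the true size of both new steps undetermined. On these data alone, how an unsubstituted phenyl, a pyridine ring, a methoxy-bearing phenyl or a longer saturated chain on the carbonyl carbon would read out in this assay also remains open, so three compounds give only a narrow view of this position.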